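Thiosemicarbazones of a terpenoid amine: growth inhibition series

The compounds below may be only part of what the source reports. "The series", "measured", "known", "first", "only" and "open" are said of these compounds alone.

Measured compounds:
Compound 1 `CC1=CC[C@H](C(C)(C)N=C=S)CC1`: > 100000 nM
Compound 2 `COc1ccc(/C=N/NC(=S)NC(C)(C)[C@H]2CC=C(C)CC2)cc1`: 50400 nM
Compound 3 `CC1=CC[C@H](C(C)(C)NC(=S)N/N=C/c2ccc(Cl)cc2)CC1`: 97400 nM

In a functional assay on NCI/ADR-RES cells (Homo sapiens) for inhibition, read by sulforhodamine B assay, with a stated time of 48 h (a higher number here means a weaker inhibitor of growth, a lower number a stronger inhibitor of growth), compound 1 gives only a limit, (the limit of > 100000 nM in this assay, at which 1 of the 3 values shown sits). Compound 2, the 4-methoxyphenyl thiosemicarbazone, gives 50400 nM in this assay. Compound 3, which carries chloro in place of methoxy on an aromatic carbon, gives 97400 nM, and a 1.9-fold higher number from compound 2 to compound 3 (0.29 log units; within the scatter), so the two sit within the scatter of each other. Compound 2 is therefore the point of departure: its number is one of only two real numbers shown, and it is not separable from that of compound 3.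

Compound 4 `CC1=CC[C@H](C(C)(C)NC(=S)N/N=C/c2cccs2)CC1` has not yet been measured. It differs from compound 2 as follows: thiophen-2-yl in place of 4-methoxyphenyl on a carbon with a double bond to nitrogen. Among the measured compounds shown here, the only measured step on the aromatic end of the molecule, from compound 2 to compound 3, stayed within the scatter, which supports an expectation of no step beyond the scatter here either. Because the step of a 1.9-fold higher number from compound 2 to compound 3 (0.29 log units; within the scatter) was small, a similar number is expected. For compound 4 the expected value in this assay is 65000 nM, within 28000 nM to 150000 nM. The expected step is a 1.3-fold higher number from compound 2 to compound 4 (0.11 log units; within the scatter), which would remain within the scatter.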

Compound 4, concentration for total growth inhibition: 41000 nM
For compound 4 the middle estimate is 1.6-fold (0.20 log units) above the measured one; the range from low to high includes it.
By their numbers in this assay, from the lowest: compounds 4, 2 and 3 (each within the scatter of the next, the first and the last beyond it). At a limit, above all of these: compound 1.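

In this assay, the place on a carbon with a double bond to nitrogen takes a five-membered aromatic ring with 1 hetero atom as well as a six-membered aromatic ring of carbon only, with thiophen-2-yl in place of 4-methoxyphenyl giving a 1.2-fold lower number from compound 2 to compound 4 (0.09 log units; within the scatter). Set against the 4-chlorophenyl group, the same thiophen-2-yl gives a 2.4-fold lower number from compound 3 to compound 4 (0.38 log units; beyond the scatter), the only step at this place that lies beyond the scatter, so the aromatic group here can shift the number, though modestly. Nothing measured in this series accounts for that shift.

Still open, from the compounds shown here alone, is whether a pyridine ring, or a phenyl ring carrying an amine or a carboxylic acid, at this place would move the number further. Also open, going by these compounds, is how much the terpenoid end, shared by compound 2, compound 3 and compound 4, contributes.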